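The source may hold more compounds than are shown below. What is called first, only, known or untested is meant among the compounds shown, and "the series" means these compounds.

Compound 1, `O=c1[nH]c(=O)n(C2COC(CO)C(O)C2)cc1-c1cccs1`, was tested in a functional assay on E6SM cells (Homo sapiens) for cytotoxicity, read by microscopy (a lower number here means that less compound is tolerated, a higher number that more compound is tolerated), and reached only a limit of the assay, > 400 ug/mL.
Compound 2, `C=Cc1cn(C2COC(CO)C(O)C2)c(=O)[nH]c1=O`, likewise reached only a limit of the assay, > 400 ug/mL.

Among the measured compounds shown here, compound 2 therefore stands at the top of what this assay can report: both values shown sit at the limit of > 400 ug/mL in this assay, at which 2 of the 2 values shown sit, and the only measured step, a step that the two limits leave unreadable from compound 1 to compound 2, cannot be read in size or direction because both of its ends are limits.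

Compound 3, `CC#Cc1cn(C2COC(CO)C(O)C2)c(=O)[nH]c1=O`, is the next compound and differs from compound 2 by prop-1-yn-1-yl in place of vinyl on an aromatic carbon. For the measured compounds named here, the only measured step that bears on this change is the one from compound 1 to compound 2, and it gives no readable size; it shows only that the two limits were reached by both compounds. No direction can therefore be read for the step in this assay, and the step from compound 2 to compound 3 is expected to be a number no higher from compound 2 to compound 3 (the limit leaves the size open), that is, none beyond the scatter. Compound 3 is accordingly estimated at 400 ug/mL, with a range from 200 ug/mL to 800 ug/mL, and most likely to be reported again only as a limit.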

Compound 3, minimum cytotoxic concentration: > 400 ug/mL
Compound 3: a limit, no number (the forecaster's own chance of this, stated with the estimate: 85%); the middle value sits exactly at the limit.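

In this assay compound 3 gives > 400 ug/mL which is a limit of the assay and not a number. Among the compounds shown here, no step among compound 1, compound 2 and compound 3 can be read in size or direction: the limit of > 400 ug/mL in this assay, at which 3 of the 3 values shown sit.
The compounds shown leave open whether thiophen-2-yl, vinyl and prop-1-yn-1-yl differ at all in the concentration tolerated in this assay.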